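Amide to Urea Where the Readout Is Only a Limit

This account rests on a few compounds, and the source may have more. Where it says the series, first, only, none or still open, it means among the compounds named here.

Compound 1 `COc1cc(-c2nn(-c3cccc(NC(=O)c4cccc(C(F)(F)F)c4)c3)cc2-c2ccncc2)ccc1Cl` is the only one of the three measured compounds that gives a number: in a functional assay on NCI-H226 cells (Homo sapiens) for inhibition, read by sulforhodamine B assay, with a stated time of 48 h (a higher number here means a weaker inhibitor of growth, a lower number a stronger inhibitor of growth), compound 1 gives 27000 nM. Compound 2 `COc1cc(-c2nn(-c3cccc(NC(=O)Nc4ccc(Cl)c(Cl)c4)c3)cc2-c2ccncc2)ccc1Cl` is its urea counterpart with a different aryl group; in this assay compound 2 reaches only the assay limit, > 50000 nM. Compound 3 `COc1cc(-c2nn(-c3cccc(NC(=O)c4ccc(Cl)c(C(F)(F)F)c4)c3)cc2-c2ccncc2)ccc1Cl` carries the amide of compound 1 with an added chloro; in this assay compound 3 also sits at a limit, > 32500 nM. Compound 3 therefore stands at the limit of > 32500 nM in this assay, at which 1 of the 3 values shown sits, and nothing more is known of it.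

Compound 4 `COc1cc(-c2nn(-c3cccc(NC(=O)Nc4ccc(Cl)c(C(F)(F)F)c4)c3)cc2-c2ccncc2)ccc1Cl` differs from compound 3 in one place: (4-chloro-3-(trifluoromethyl)phenyl)amino in place of 4-chloro-3-(trifluoromethyl)phenyl on a carbonyl carbon. The same kind of change, amide to urea, has been measured once as an at least 1.8-fold higher number from compound 1 to compound 2 (0.26 log units; that floor lies within the scatter), ending at the limit of > 50000 nM in this assay, at which 1 of the 3 values shown sits. The step of an at least 1.2-fold higher number from compound 1 to compound 3 (0.08 log units; that floor lies within the scatter) adds little, and a step that the two limits leave unreadable from compound 2 to compound 3. The analyst therefore expects compound 4 to stay at or beyond the limit, the expected step that the limit leaves unreadable from compound 3 to compound 4 pointing toward weaker inhibition or none beyond the scatter. The estimate for compound 4 in this assay is 60000 nM, expected between 30000 nM and 120000 nM.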

Compound 4, concentration for total growth inhibition: > 32500 nM
Compound 4 gave a limit, no number (the forecaster's own chance of this, stated with the estimate: 90%); the middle value is on the limit's open side.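

In this assay compound 4 gives a limit and no number, and it shares that limit with compound 3: the limit of > 32500 nM in this assay, at which 2 of the 4 values shown sit. This is the first amide-to-urea pair shown with the 4-chloro-3-(trifluoromethyl)phenyl group held constant, yet the steps from compound 3 to compound 4 and from compound 2 to compound 4 cannot be read, so the change from amide to urea still has no measurable size at this position. The only readable step is an at least 1.2-fold higher number from compound 1 to compound 4 (0.08 log units; that floor lies within the scatter), and both ureas shown, compound 2 and compound 4, give limits and no number.

From the compounds shown here alone, how far compound 2, compound 3 and compound 4 truly lie from compound 1 remains open. So does whether a dimethylamino group or a carboxylic acid in place of the chloro on the urea of compound 4 would give a number in this assay.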